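Chlorophenyl for Furan in a Cytotoxicity Series

A few compounds are considered here, and "the series" means these few. Any claim that something is new, unique, unknown or untested is made for them only; others in the source may bear on it.

Compound 1 `CC(C)COc1cccc(-c2ccc(C(=O)N(Cc3cccc(OCCCCCC(=O)O)c3)C(C)C)cc2)c1` gives > 26000 nM in an ADME assay on Raji cells (Homo sapiens) for cytotoxicity, read by CellTiter-Glo and resazurin assay, with a stated time of 72 h; a higher number here means that more compound is needed for the effect, a lower number that less compound is needed; this is a limit of the assay, not a number.
Compound 2 `CC(C)N(Cc1cccc(OCCCCCC(=O)O)c1)C(=O)c1ccc(-c2ccco2)cc1` gives > 26000 nM in this assay; this too is a limit.
Compound 3 `CCOC(=O)CCCCCOc1cccc(CN(C(=O)c2ccc(-c3ccco3)cc2)C(C)C)c1` gives > 26000 nM in this assay; again a limit.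

All three measured compounds sit at the limit of > 26000 nM in this assay, at which 3 of the 3 values shown sit, so none of them shows cytotoxicity within the range tested. Compound 3 therefore stands only at a limit, with no number of its own, and the two other values shown are limits as well. The steps between the measured compounds cannot be sized: a step that the two limits leave unreadable from compound 1 to compound 2 and a step that the two limits leave unreadable from compound 2 to compound 3 are both left unreadable because all three values rest at the limit of > 26000 nM in this assay, at which 3 of the 3 values shown sit.

Compound 4 `CCOC(=O)CCCCCOc1cccc(CN(C(=O)c2ccc(-c3cccc(Cl)c3)cc2)C(C)C)c1` differs from compound 3 by 3-chlorophenyl in place of furan-2-yl on an aromatic carbon. Of the measured steps, only the change from compound 1 to compound 2 also swapped a group on an aromatic carbon, and since it is unreadable it offers no direction for this new change. With no readable step in this assay and every measured compound at the limit, no shift beyond the scatter is expected in either direction. Compound 4 is therefore expected to stay at the limit, estimated at 40000 nM with a range of 15000 nM to 120000 nM. The step this estimate implies, a step that the limit leaves unreadable from compound 3 to compound 4, is expected to be no real movement at all.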

Compound 4, half-maximal effective concentration: > 18400 nM
Compound 4 gave a limit, no number (the forecaster's own chance of this, stated with the estimate: 85%); the middle value is on the limit's open side.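

In this assay compound 4 gives > 18400 nM, which is a limit and not a number. Compound 3 also stands at a limit, so the effect of 3-chlorophenyl in place of furan-2-yl between compound 3 and compound 4 cannot be read. The compounds shown leave open whether any of them has a cytotoxic effect at a concentration that can be given as a number.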